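Aryl replacement at the chain end: compound 3 to compound 4

This account rests on a few compounds, and the source may have more. Where it says the series, first, only, none or still open, it means among the compounds named here.

Three analogues share one core and differ only in the aryl group on the double-bonded chain carbon. In a functional assay on PC-3 cells (Homo sapiens) for cytotoxicity, read by MTT assay, with a stated time of 72 h (on this read-out higher numbers stand for weaker inhibition and lower numbers for stronger inhibition), compound 1 `COc1ccc(OC)c(/C=C/C(=O)Nc2cc3c(Nc4ccc(F)c(Cl)c4)ncnc3cc2O[C@H]2CCOC2)c1` gives 8730 nM, compound 2 `COc1cc(/C=C/C(=O)Nc2cc3c(Nc4ccc(F)c(Cl)c4)ncnc3cc2O[C@H]2CCOC2)cc(OC)c1O` gives 26500 nM, and compound 3 `COc1ccc(/C=C/C(=O)Nc2cc3c(Nc4ccc(F)c(Cl)c4)ncnc3cc2O[C@H]2CCOC2)c(OC)c1OC` gives 7670 nM. Compound 3 holds the lowest of the three numbers: a 1.1-fold lower number from compound 1 to compound 3 (0.06 log units; within the scatter), whereas a 3.5-fold lower number from compound 2 to compound 3 (0.54 log units; beyond the scatter). Compound 4 `O=C(/C=C/c1ccc(Br)cc1)Nc1cc2c(Nc3ccc(F)c(Cl)c3)ncnc2cc1O[C@H]1CCOC1` differs by 4-bromophenyl in place of 2,3,4-trimethoxyphenyl on a double-bonded chain carbon bound to a double-bonded chain carbon. The measured steps only rearrange methoxy and hydroxy groups on this ring, and a 3.0-fold higher number from compound 1 to compound 2 (0.48 log units; beyond the scatter) is the largest of them. Among the compounds with values here, no measured step replaces the whole methoxylated ring by a halophenyl, so for compound 4 the expectation is a step no larger than modest in either direction, a 1.2-fold higher number from compound 3 to compound 4 (0.07 log units; within the scatter). Compound 4 is therefore estimated at 9000 nM, in a range from 3000 nM to 30000 nM.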

Compound 4, half-maximal inhibitory concentration: 28200 nM
For compound 4 the middle estimate is 3.1-fold (0.50 log units) below the measured one; the measured number falls inside the stated range.
By their numbers in this assay, from the lowest: compounds 3 and 1 (each within the scatter of the next); then compounds 2 and 4 (each within the scatter of the next).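

In this assay, 4-bromophenyl at this place gives a weaker result than either the 2,3,4-trimethoxyphenyl or the 2,5-dimethoxyphenyl ring (a 3.7-fold higher number from compound 3 to compound 4 (0.57 log units; beyond the scatter); a 3.2-fold higher number from compound 1 to compound 4 (0.51 log units; beyond the scatter)). Against 4-hydroxy-3,5-dimethoxyphenyl, the replacement shows no resolved difference (a 1.1-fold higher number from compound 2 to compound 4 (0.03 log units; within the scatter)), so a ring without oxygen substituents can match the hydroxylated one here. No measured evidence accounts for these steps.

On these data alone, whether the bromine or the loss of the methoxy groups sets this result remains open. So does the effect of an amine or a carboxylic acid on this phenyl ring.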